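This account rests on a few compounds, and the source may have more. Where it says the series, first, only, none or still open, it means among the compounds named here.

Measured compounds:
compound 1 `COc1ccc(-c2c(C)nn(-c3nc(-c4ccc(Cl)c(Cl)c4)c(SC(C)C)s3)c2C(=O)O)cc1`, 2100 nM
compound 2 `COc1ccc(C)cc1-c1c(C)nn(-c2nc(-c3ccc(Cl)c(Cl)c3)c(SC(C)C)s2)c1C(=O)O`, 9500 nM
compound 3 `Cc1nn(-c2nc(-c3ccc(Cl)c(Cl)c3)c(SC(C)C)s2)c(C(=O)O)c1-c1cc(C#N)cc(C(F)(F)F)c1`, 3600 nM

In a functional assay on BJAB cells (Homo sapiens) for antiproliferative activity, with a stated time of 4 days (on this read-out higher numbers stand for an effect only at larger amounts of compound and lower numbers for an effect already at smaller amounts), compound 2 gives the highest of the three numbers; compound 3 is nearer to it and compound 1 furthest away, both steps beyond the scatter. Compound 4 `Cc1nn(-c2nc(-c3ccc(Cl)c(Cl)c3)c(SC(C)C)s2)c(C(=O)O)c1-c1cnn(C)c1` is not yet measured. Its change from compound 2 is 1-methyl-1H-pyrazol-4-yl in place of 2-methoxy-5-methylphenyl on an aromatic carbon. Among the compounds with values here, two measured steps bear on this position: a 4.5-fold higher number from compound 1 to compound 2 (0.66 log units; beyond the scatter) and a 2.6-fold lower number from compound 2 to compound 3 (0.42 log units; beyond the scatter). Both show that exchanging the 2-methoxy-5-methylphenyl of compound 2 for another group gave a lower number. No aryl as small as 1-methyl-1H-pyrazol-4-yl has been tried, so the expectation is tentative. Compound 4 is therefore expected at 4000 nM, within 1500 nM to 12000 nM. That estimate means an expected 2.4-fold lower number from compound 2 to compound 4 (0.38 log units; beyond the scatter), a modest downward step.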

Compound 4, half-maximal effective concentration: 6800 nM
Beside the measured number, compound 4's estimate is 1.7-fold (0.23 log units) below it; the measured number falls inside the stated range.
By their numbers in this assay, from the lowest: compounds 1, 3, 4 and 2 (each within the scatter of the next, the first and the last beyond it).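

In this assay, a 1.4-fold lower number from compound 2 to compound 4 (0.15 log units; within the scatter) and a 1.9-fold higher number from compound 3 to compound 4 (0.28 log units; within the scatter), so 1-methyl-1H-pyrazol-4-yl cannot be told apart from 2-methoxy-5-methylphenyl or 3-cyano-5-(trifluoromethyl)phenyl, while a 3.2-fold higher number from compound 1 to compound 4 (0.51 log units; beyond the scatter) separates it from 4-methoxyphenyl. Within the data shown here, a five-membered aromatic ring with 2 hetero atoms at this position therefore leaves the number within the span set by the earlier compounds. No measurement at hand accounts for these steps. On these data alone, whether a pyridin-4-yl or an unsubstituted phenyl here would give a number lower than that of compound 1 remains open.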